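The source may report more compounds than this note shows. Statements on the series, on what has been measured and on what is new or still open speak of the compounds shown alone.

The study centres on a shared core carrying a methyl group, seen in compound 1 `Cc1cc2ccccc2nc1-c1cn(CCC(F)(F)C(F)(F)C(F)(F)C(F)(F)C(F)(F)C(F)(F)C(F)(F)C(F)(F)F)nn1` and compound 2 `Cc1cc2ccccc2nc1-c1cn(-c2ccc(F)cc2)nn1`, and on its cytotoxicity in a functional assay on COLO 205 cells (Homo sapiens) for cytotoxicity, read by MTT assay, with a stated time of 24 h; a higher number here means a weaker inhibitor, a lower number a stronger inhibitor. In this assay compound 1 gives 75.8 ug/mL. Compound 2, in turn, reaches only the limit of the assay, > 100 ug/mL, so no number is known for it; this is the case described by the limit of > 100 ug/mL in this assay, at which 1 of the 2 values shown sits, and its place among the values shown is therefore at the top, beyond where compound 1 sits. Compound 3 `CCCCCc1cc2ccccc2nc1-c1cn(-c2ccc(F)cc2)nn1` is not yet measured. It differs from compound 2 by butyl in place of hydrogen on a saturated chain carbon bound to an aromatic carbon. Going by the values given here, with no measured step of this kind, a step from compound 2 to compound 3 of modest size, toward a stronger inhibitor, is expected, an at least 1.6-fold lower number from compound 2 to compound 3 (0.22 log units; that floor lies within the scatter). Compound 3 is accordingly estimated at 60 ug/mL, between 25 ug/mL and 150 ug/mL.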

Compound 3, half-maximal inhibitory concentration: > 100 ug/mL
Compound 3: only a limit was reported; the forecaster's own chance of this, stated with the estimate: 40%; middle value at least 1.6-fold (0.22 log units) from the limit.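

No step can be read from compound 2 to compound 3, because both stand only as limits of the assay: the limit of > 100 ug/mL in this assay, at which 2 of the 3 values shown sit.

The compounds shown leave open whether butyl in place of hydrogen on a saturated chain carbon bound to an aromatic carbon changes cytotoxicity at all, and how far beyond that limit compound 2 and compound 3 lie.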